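The source may hold more compounds than are shown below. What is called first, only, known or untested is meant among the compounds shown, and "the series" means these compounds.

In a functional assay on MCF7 cells (Homo sapiens) for antiproliferative activity, read by MTT assay, with a stated time of 72 h (on this read-out lower numbers stand for stronger inhibition and higher numbers for weaker inhibition), compound 1 (`CC(Nc1ncnc2ccc(-c3cnn(C4CCNCC4)c3)cc12)c1c(Cl)ccc(F)c1Cl`) gives 2650 nM and compound 2 (`CC(Nc1ncnc2ncc(-c3cnn(C4CCNCC4)c3)cc12)c1c(Cl)ccc(F)c1Cl`) gives 1630 nM and these two values sit within the usual scatter of each other, so the two compounds cannot be told apart. Compound 3 (`CC(Nc1ncnc2ncc(-c3cnn(C)c3)cc12)c1c(Cl)ccc(F)c1Cl`) differs from compound 2 in one place, with methyl in place of piperidin-4-yl on an aromatic nitrogen as the change. For the measured compounds named here, no measured pair shows what this change does, so only a moderate rise in the number in this assay is expected, meaning weaker inhibition. The estimated move is a 2.5-fold higher number from compound 2 to compound 3 (0.39 log units; beyond the scatter) and it remains a rough expectation. Compound 3 is estimated at 4000 nM with 1500 nM to 11000 nM as the expected range.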

Compound 3, half-maximal inhibitory concentration: > 100000 nM
Compound 3: only a limit was reported; the forecaster's own chance of this, stated with the estimate: 15%; middle value at least 25-fold (1.39 log units) from the limit.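

On the aromatic nitrogen of the five-membered ring, the group turns out to matter greatly: replacing piperidin-4-yl with methyl gives an at least 61-fold higher number from compound 2 to compound 3 (1.78 log units; beyond the scatter). In this assay compound 3 gives > 100000 nM, which is a limit and not a number. The true size of the step is therefore bounded on one side only: the limit of > 100000 nM in this assay, at which 1 of the 3 values shown sits.

From the compounds shown here alone, what stays open is whether the piperidine ring itself or its nitrogen carries the effect. A cyclohexyl ring, with no nitrogen, or an aminoethyl chain, with a nitrogen but no ring, would separate the two.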